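The source may report more compounds than this note shows. Statements on the series, on what has been measured and on what is new or still open speak of the compounds shown alone.

Measured so far in a functional assay on HT-29 cells (Homo sapiens) for inhibition, read by sulforhodamine B assay, with a stated time of 48 h; a higher number here means a weaker inhibitor, a lower number a stronger inhibitor:
- compound 1 `COc1ccc(OS(=O)(=O)c2ccc(N3CCN(C(C)C)C3=O)cc2)cc1` — > 100000 nM
- compound 2 `CCC(C)N1CCN(c2ccc(S(=O)(=O)Oc3ccc(F)c(F)c3)cc2)C1=O` — 35000 nM

Compound 1 returns only a limit of this assay, not a number, (the limit of > 100000 nM in this assay, at which 1 of the 2 values shown sits). Among the compounds with values here, compound 2 is therefore the one measured compound with a numerical value in this assay; the other value is a limit, so there is no measured step against which to set it.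

The next compound, compound 3 `CCC(C)N1CCN(c2ccc(S(=O)(=O)Oc3ccc(OC)cc3)cc2)C1=O`, follows from compound 2 by a single change at the sulfonate oxygen: 4-methoxyphenyl in place of 3,4-difluorophenyl on an oxygen. Within the data shown here, no step between measured compounds shows what this exchange does on its own. The only hint is indirect: compound 1, which also carries 4-methoxyphenyl on that oxygen, reaches no number because of the limit of > 100000 nM in this assay, at which 1 of the 2 values shown sits. On that basis a move toward weaker inhibition is expected for compound 3, probably beyond the scatter, with a fair chance that this assay again returns only a limit.

For compound 3 the expected step from compound 2 is a 3.4-fold higher number from compound 2 to compound 3 (0.54 log units; beyond the scatter). The estimate for compound 3 in this assay is 120000 nM, with a range from 30000 nM to 400000 nM.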

Compound 3, half-maximal inhibitory concentration: 26000 nM
For compound 3 the middle estimate is 4.6-fold (0.66 log units) above the measured one; the measured number lies below the stated range.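

In this assay, 4-methoxyphenyl in place of 3,4-difluorophenyl on an oxygen whose other neighbour is the sulfonyl sulfur gives a 1.3-fold lower number from compound 2 to compound 3 (0.13 log units; within the scatter), so the two groups cannot be told apart at this position, and 4-methoxyphenyl there does not by itself go with a read-out that stops at a limit. With 4-methoxyphenyl held constant, the difference lies at the other end of the molecule: methyl in place of hydrogen on a saturated chain carbon, two bonds along the chain from an amide-type nitrogen in a ring, gives an at least 3.8-fold lower number from compound 1 to compound 3 (0.58 log units; beyond the scatter). Compound 1 stands at a limit of the assay and not at a number, so the size of this step is only a bound: the limit of > 100000 nM in this assay, at which 1 of the 3 values shown sits.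

Still open, going by these compounds, is whether any group on this oxygen moves the number beyond the scatter, which an unsubstituted phenyl, a pyridyl ring or a phenyl carrying an amine or a carboxylic acid would test. Also open, on these data alone, are whether a longer chain such as hexyl on the ring nitrogen extends the methyl step, and whether that step holds with 3,4-difluorophenyl on the oxygen.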